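The source may hold more compounds than are shown below. What is called first, only, known or untested is meant among the compounds shown, and "the series" means these compounds.

Measured compounds:
Compound 1, `COc1ccc(N2CC(c3ccc([N+](=O)[O-])cc3)=[N+]([O-])C2c2ccc(N(C)C)cc2)cc1` — 2.32
Compound 2, `O=[N+]([O-])c1ccc(C2=[N+]([O-])C(c3ccccc3)N(C3CCCCC3)C2)cc1` — 2.41
Compound 3, `O=[N+]([O-])c1ccc(C2=[N+]([O-])C(c3ccccc3)N(c3ccccc3)C2)cc1` — 2.45

In a physicochemical assay for lipophilicity (on this read-out lower numbers stand for lower lipophilicity and higher numbers for higher lipophilicity), compound 1 stands at the low end of these three numbers, with compound 2 and compound 3 both a little higher, though all three lie within the scatter of one another, so no order among them can be read from the numbers. For the measured compounds named here, the only measured step between two compounds that differ in one place is a number 0.04 log units higher from compound 2 to compound 3 (within the scatter), and it does not reach beyond the scatter.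

Compound 4, `CN(C)c1ccc(C2N(Cc3ccccc3)CC(c3ccc([N+](=O)[O-])cc3)=[N+]2[O-])cc1`, differs from compound 1 in one place: benzyl in place of 4-methoxyphenyl on an amine nitrogen in a ring. Going by the values given here, none of the measured steps covers this exchange; the step from compound 2 to compound 3 swaps groups on the same ring nitrogen but exchanges different groups, so it offers only loose guidance that changes at this position have stayed small. On that basis the step of a number 0.18 log units higher from compound 1 to compound 4 (within the scatter) is expected to be small, and in this assay compound 4 is estimated at 2.5, somewhere between 2.1 and 2.9.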

Compound 4, partition coefficient: 2.02
Beside the measured number, compound 4's estimate is 0.48 log units above it; measured number below the stated range.
By their numbers in this assay, from the lowest: compounds 4, 1, 2 and 3 (each within the scatter of the next, the first and the last beyond it).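

Putting benzyl, which has no oxygen, in place of 4-methoxyphenyl on the amine nitrogen in the ring gives a number 0.30 log units lower from compound 1 to compound 4 (within the scatter) in this assay. Alongside a number 0.04 log units higher from compound 2 to compound 3 (within the scatter), this makes two different exchanges at this nitrogen, and neither step goes beyond the usual scatter, so the numbers do not separate any of these four groups from the one it replaced. Nothing available explains the size of the new step.

Still open, going by these compounds, is whether a group of another kind on this nitrogen, such as a longer chain ending in an amine or a carboxylic acid, would also stay within the scatter. On these data alone, it is also open whether benzyl in place of 4-methoxyphenyl would give a similar step if the other groups on the core were different.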